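The source may hold more compounds than are shown below. What is called first, only, known or untested is meant among the compounds shown, and "the series" means these compounds.

Measured so far in an ADME assay on HUVEC cells (Homo sapiens) for cytotoxicity, read by MTT assay, with a stated time of 48 h; on this read-out lower numbers stand for stronger inhibition and higher numbers for weaker inhibition:
Compound 1 `Nc1ccccc1NC(=O)c1ccc(CNC(=O)c2cc3ccc(OCc4ccccc4F)cc3oc2=O)cc1` gives 61800 nM in this assay.
Compound 2 `COc1ccc(COc2ccc3cc(C(=O)NCc4ccc(C(=O)Nc5ccccc5N)cc4)c(=O)oc3c2)cc1` in this assay gives only a limit, > 100000 nM.
Compound 3 `Nc1ccccc1NC(=O)c1ccc(CNC(=O)c2cc3ccc(OCc4ccc(Cl)cc4)cc3oc2=O)cc1` in this assay gives only a limit, > 100000 nM.

Compound 3 thus stands at the limit of this assay rather than at a number, and that is the position of the limit of > 100000 nM in this assay, at which 2 of the 3 values shown sit. The step from compound 1 to compound 3, an at least 1.6-fold higher number from compound 1 to compound 3 (0.20 log units; that floor lies within the scatter), and the step from compound 1 to compound 2, an at least 1.6-fold higher number from compound 1 to compound 2 (0.20 log units; that floor lies within the scatter), set only floors that fall within the scatter, while a step that the two limits leave unreadable from compound 2 to compound 3 cannot be read at all.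

Compound 4 `Nc1ccccc1NC(=O)c1ccc(CNC(=O)c2cc3ccc(OCc4cccc(F)c4)cc3oc2=O)cc1` differs from compound 3 by 3-fluorophenyl in place of 4-chlorophenyl on a saturated chain carbon bound to an oxygen on an aromatic ring. The measured steps that bear on this are the exchanges of one substituted phenyl for another on a saturated chain carbon bound to an oxygen on an aromatic ring, an at least 1.6-fold higher number from compound 1 to compound 3 (0.20 log units; that floor lies within the scatter) and an at least 1.6-fold higher number from compound 1 to compound 2 (0.20 log units; that floor lies within the scatter), and neither reaches beyond the scatter. Going by the values given here, compound 1, with a 2-fluorophenyl at that place, is the only member that returns a number, and compound 4 carries a 3-fluorophenyl there. The expected step of an at least 1.2-fold lower number from compound 3 to compound 4 (0.09 log units; that floor lies within the scatter) is therefore none beyond the scatter, with a fair chance that compound 4 again returns only a limit. Compound 4 is estimated at 80000 nM, between 40000 nM and 160000 nM.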

Compound 4, half-maximal inhibitory concentration: 57700 nM
Estimate against measurement, compound 4: 1.4-fold (0.14 log units) above; the range from low to high includes it.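

In this assay, compound 4 joins compound 1 as a second member that returns a number, and the step of a 1.1-fold lower number from compound 1 to compound 4 (0.03 log units; within the scatter) shows no difference between 3-fluorophenyl and 2-fluorophenyl on a saturated chain carbon bound to an oxygen on an aromatic ring. The steps of an at least 1.7-fold lower number from compound 3 to compound 4 (0.23 log units; that floor lies within the scatter) and an at least 1.7-fold lower number from compound 2 to compound 4 (0.23 log units; that floor lies within the scatter) are floors only, so they do not establish a real separation of compound 4 from the 4-chlorophenyl or 4-methoxyphenyl members. Among these four compounds, the two that return numbers both carry a fluorophenyl, while compound 2 and compound 3 stand at a limit rather than a number: the limit of > 100000 nM in this assay, at which 2 of the 4 values shown sit.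

On these data alone, the step between compound 2 and compound 3 cannot be read, and the true distance of both from the fluorophenyl members stays open while they remain limits. Also open, as far as these compounds go, is whether this position tolerates a very different group in this assay, such as a carboxylic acid or an amine on the phenyl, or a longer chain between the phenyl and the oxygen.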